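This account rests on a few compounds, and the source may have more. Where it says the series, first, only, none or still open, it means among the compounds named here.

Compound 1 `Cc1nc(-c2cccs2)sc1COc1ccc2c(c1)OCC2CC(=O)O`: in a functional assay on CHO cells for agonist activity at Free fatty acid receptor 1 (Homo sapiens), read by FLIPR and calcium flux (on this read-out lower numbers stand for an effect already at smaller amounts and higher numbers for an effect only at larger amounts of compound), compound 1 gives "not determined" (no result reported).
Compound 2 `Cc1nc(-c2ccsc2)sc1COc1ccc2c(c1)OCC2CC(=O)O`: in this assay compound 2 gives 68.5 nM.
Compound 3 `Cc1nc(-c2cccc3ccccc23)sc1COc1ccc2c(c1)OCC2CC(=O)O`: in this assay compound 3 gives "not determined" (no result reported).

On the numbers shown, compound 3 stands nowhere: it has no single number in this assay, and compound 1 is in the same position, so the only number in the set belongs to compound 2. Compound 4 `Cc1cccc(-c2nc(C)c(COc3ccc4c(c3)OCC4CC(=O)O)s2)c1` is built from compound 3 by one change, (3-methylphenyl in place of naphthalen-1-yl on an aromatic carbon), so that a smaller, single-ring group now sits where the two-ring group sat. Within the data shown here, no step between two measured compounds exists in this set, so the size and direction of the change from compound 3 to compound 4 cannot be read from any measured pair; the shared core is the same as in compound 2, whose value is the only anchor. Because compound 2 gives 68.5 nM, compound 4 is expected to land in a similar region, with wide uncertainty, and its value in this assay is estimated at 45 nM, with a range from 10 nM to 250 nM.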

Compound 4, half-maximal effective concentration: 119 nM
Estimate against measurement, compound 4: 2.6-fold (0.42 log units) below; measured number inside the range.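

In this assay, among these compounds, the one step that can be read is a 1.7-fold higher number from compound 2 to compound 4 (0.24 log units; within the scatter), with 3-methylphenyl in place of thiophen-3-yl on the aromatic carbon that lies next to both the ring nitrogen and the ring sulfur. Among the compounds shown here, the earlier compounds offered only a single number at this position; now there are two, and the assay does not tell these two groups apart, so a six-membered carbon ring bearing a methyl group and a thiophen-3-yl group both give a measured result here. Nothing available here explains this result.

As far as these compounds go, compound 3 has no number, so the step from naphthalen-1-yl to 3-methylphenyl cannot be read, and the effect of the second ring remains unknown. Also open, from the compounds shown here alone, is how a plain phenyl or a pyridin-3-yl group would compare at this position, which would help show whether the methyl group matters.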